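The source may report more compounds than this note shows. Statements on the series, on what has been measured and on what is new or still open speak of the compounds shown alone.

Working notes on the series, read in an ADME assay on microsomes from liver (Rattus norvegicus) for metabolic stability; a higher number here means that the compound lasts longer, a lower number that the compound disappears faster. Compound 1 `N#Cc1ccc(NCCNc2ncc(-c3ncc[nH]3)c(-c3ccc(Cl)cc3Cl)n2)nc1` gives > 0.5 h, which is a limit of the assay and not a number. Compound 2 `Nc1nc(NCCNc2ncc(-c3ncc[nH]3)c(-c3ccc(Cl)cc3)n2)ccc1[N+](=O)[O-]` gives > 0.5 h, which is also a limit and not a number. Compound 2 therefore stands at the limit of > 0.5 h in this assay, at which 2 of the 2 values shown sit, and no exact half-life is available for it.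

Compound 3 `Nc1nc(NCCNc2ncc(-c3ncc[nH]3)c(-c3ccccc3Br)n2)ccc1[N+](=O)[O-]` keeps the rest of compound 2 and changes one group: 2-bromophenyl in place of 4-chlorophenyl on an aromatic carbon. This puts 2-bromophenyl in place of 4-chlorophenyl on an aromatic carbon, ortho to a 1H-imidazol-2-yl group. Among the measured compounds shown here, no pair of measured compounds differs in one place, so the data give no direct size for this change. A step beyond the usual scatter is not expected in this assay, and neither direction is favoured. The only anchor for this expectation is compound 2 at > 0.5 h, itself a limit. The estimated change is a step that the limit leaves unreadable from compound 2 to compound 3. For compound 3 the estimated half-life is 0.6 h, with an expected range from 0.3 h to 1.2 h. A report as a limit, rather than a number, is also expected to be more likely than not.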

Compound 3, half-life: > 0.5 h
Compound 3: a limit, no number; the forecaster's own chance of this, stated with the estimate: 60%; the middle value does not contradict the limit.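

In this assay compound 3 gives > 0.5 h, a limit and not a number. Among the compounds shown here, compound 2 is also reported as a limit, so no step between compound 2 and compound 3 can be read. Still open are the actual half-lives of these compounds and whether 2-bromophenyl in place of 4-chlorophenyl changes the half-life at all: the limit of > 0.5 h in this assay, at which 3 of the 3 values shown sit.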